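Removing one hydroxy group from a chalcone-type topoisomerase inhibitor

The source may report more compounds than this note shows. Statements on the series, on what has been measured and on what is new or still open speak of the compounds shown alone.

The compounds measured so far:
compound 1, `O=C(/C=C/c1ccc(N2CCCC2)cc1)c1ccc(O)cc1O`, 87.1%
compound 2, `COc1ccc(/C=C/C(=O)c2ccc(O)cc2O)cc1Br`, 73.2%
compound 3, `COc1ccc(/C=C/C(=O)c2ccco2)cc1Br`, 92%

All three were tested in an assay on isolated protein for inhibition of DNA topoisomerase 1 (Homo sapiens), tested at 100 uM; a higher number here means a stronger effect of the compound at the concentration tested, a lower number a weaker effect. Compound 1 gives 87.1% in this assay. Its number and that of compound 3, 92%, lie within the usual scatter of each other, so no order can be read between them. Compound 2, with 73.2%, sits lower than compound 1 by more than the scatter. None of these three pairs differs in only one place, so no single structural change can be tied to any of these gaps.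

The step of interest goes from compound 1 to compound 4, `O=C(/C=C/c1ccc(N2CCCC2)cc1)c1ccc(O)cc1`. The change is hydrogen in place of hydroxy on an aromatic carbon: a hydroxy that sits ortho to a large group and meta to a hydroxy group is exchanged for hydrogen. Going by the values given here, no measured pair shows what such an exchange does here, so the direction and size of the step are not known from the data. Because compound 1 already gives 87.1%, the room upward is small, and a modest fall seems the more likely outcome, though a step that stays within the scatter cannot be ruled out. Compound 4 is expected to give 74% in this assay, within 55% to 92%. The expected step is therefore a number 13.1 percentage points lower from compound 1 to compound 4 (beyond the scatter).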

Compound 4, a percentage reported as inhibition, at one concentration (the size of the read-out at that concentration, not a potency): 74.7%
Estimate against measurement, compound 4: 0.7 percentage points below; the range from low to high includes it.
By their numbers in this assay, from the lowest: compounds 2 and 4 (each within the scatter of the next); then compounds 1 and 3 (each within the scatter of the next).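

In this assay, going by these compounds alone, this pair gives the first reading of a single change at this position: the step is a number 12.4 percentage points lower from compound 1 to compound 4 (beyond the scatter). Within the data shown here, the exchange of hydroxy for hydrogen is the only difference between the two structures, so this gap, unlike those among the earlier compounds, can be tied to one place, and it shows that this hydroxy counts, though compound 4 still gives 74.7% at the one concentration tested, so a sizeable read-out remains without it. Nothing measured here bears on why the number falls.

On these data alone, whether a methoxy group, a fluorine atom or an amine in this place would keep the number closer to that of compound 1 remains open, and so does the effect of exchanging the other hydroxy group for hydrogen. Also open, as far as these compounds go, is whether the same exchange would produce a similar step in compound 2, which carries the same pair of hydroxy groups on a different remainder of the molecule.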